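Adding a Ring to the Side Chain of Compound 2

The compounds below may be only part of what the source reports. "The series", "measured", "known", "first", "only" and "open" are said of these compounds alone.

In a functional assay on a cell-free system (plasma, Homo sapiens) for inhibition, with Plasma (Rattus norvegicus) as the target (on this read-out lower numbers stand for stronger inhibition and higher numbers for weaker inhibition), compound 1 `CCCCOc1ccc2c(N3CCNCC3)cc(=O)oc2c1C` gives 5030 nM while compound 2 `CSCCOc1ccc2c(N3CCNCC3)cc(=O)oc2c1C` gives 1500 nM as the lower of the two numbers. Within the data shown here, compound 3 `Cc1c(OCC2CCCN(C)C2)ccc2c(N3CCNCC3)cc(=O)oc12` brings 1-methylpiperidin-3-yl in place of (methylsulfanyl)methyl on a saturated chain carbon bound to an oxygen on an aromatic ring as its only difference from compound 2. Only the modest step of a 3.4-fold lower number from compound 1 to compound 2 (0.53 log units; beyond the scatter) bears on this change. Among the measured compounds shown here, no measured compound carries a ring at this place, so a similarly modest move towards a higher number is expected in this assay with wide uncertainty. For compound 3 the estimated value is 3500 nM (expected range 900 nM to 13000 nM). The expected step is a 2.3-fold higher number from compound 2 to compound 3 (0.37 log units; beyond the scatter) on this estimate.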

Compound 3, half-maximal inhibitory concentration: 16400 nM
Beside the measured number, compound 3's estimate is 4.7-fold (0.67 log units) below it; measured number outside the range, above it.
By their numbers in this assay, from the lowest: compound 2; then compound 1; then compound 3.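

At this position, on a saturated chain carbon bound to an oxygen on an aromatic ring, 1-methylpiperidin-3-yl is poorly tolerated in this assay: replacing (methylsulfanyl)methyl gives an 11-fold higher number from compound 2 to compound 3 (1.04 log units; beyond the scatter), a large step. Replacing propyl gives a 3.3-fold higher number from compound 1 to compound 3 (0.51 log units; beyond the scatter), so the only ring-bearing side chain shown has a higher number than both open chains. Nothing measured here explains this loss.

The compounds shown leave open whether the ring or its nitrogen drives the change. Cyclohexyl, with the ring but no amine, and a 2-(dimethylamino)ethyl chain, with the amine but no ring, would separate the two.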